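This account rests on a few compounds, and the source may have more. Where it says the series, first, only, none or still open, it means among the compounds named here.

In a functional assay on WM164 cells (Homo sapiens) for antiproliferative activity, read by sulforhodamine B assay, with a stated time of 48 h; a higher number here means a weaker inhibitor, a lower number a stronger inhibitor:
- compound 1 `CCCCCCCCCCCCCCNC(=O)[C@@H]1CSC(c2cc(OC)c(OC)c(OC)c2)N1`: 1600 nM
- compound 2 `CCCCCCCCCCCCCCNC(=O)[C@@H]1CSC(c2ccc(OC)c(OC)c2)N1`: 800 nM
- compound 3 `CCCCCCCCCCCCCCCCNC(=O)[C@@H]1CSC(c2ccc(OC)c(OC)c2)N1`: 500 nM

Compound 2, at 800 nM, stands in the middle of these three numbers. Compound 4 `CCCCCCCCCCCCCCNC(=O)[C@@H]1CSC(c2ccc(NC(C)=O)cc2)N1` carries 4-acetamidophenyl in place of 3,4-dimethoxyphenyl on a saturated ring carbon. Among the compounds with values here, the nearest guide is the one measured change on the aromatic ring, a 2.0-fold lower number from compound 1 to compound 2 (0.30 log units; within the scatter). The other measured step, a 1.6-fold lower number from compound 2 to compound 3 (0.20 log units; within the scatter), concerns the chain and bears on this change less. Within the data shown here, no measured compound carries 4-acetamidophenyl, so the guide is loose. A step within the scatter is expected in this assay, leaning towards a higher number. The expected step is a 1.4-fold higher number from compound 2 to compound 4 (0.14 log units; within the scatter). For compound 4 the estimated value is 1100 nM, with an expected range of 400 nM to 3000 nM.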

Compound 4, half-maximal inhibitory concentration: 600 nM
For compound 4 the middle estimate is 1.8-fold (0.26 log units) above the measured one, within the range that was stated.
By their numbers in this assay, from the lowest: compounds 3, 4, 2 and 1 (each within the scatter of the next, the first and the last beyond it).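

In this assay the step of a 1.3-fold lower number from compound 2 to compound 4 (0.12 log units; within the scatter) shows that this saturated ring carbon can carry an aromatic group other than a methoxy-substituted phenyl without the number leaving the scatter. Until now, only the methoxy pattern on the ring had varied; here both methoxy groups leave and an acetamido group enters, bringing a hydrogen-bond donor. Nothing available explains this result. From the compounds shown here alone, it remains open whether an amine or a carboxylic acid in place of the acetamido group would give a similar number. Also open, going by these compounds, is how 4-acetamidophenyl behaves with a longer chain on the amide nitrogen.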